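The source may hold more compounds than are shown below. What is called first, only, known or untested is meant among the compounds shown, and "the series" means these compounds.

Compound 1 `CC1(C)N=C(N)N=C(N)N1c1cccc(S(N)(=O)=O)c1` and compound 2 `CC(=O)c1cccc(N2C(N)=NC(N)=NC2(C)C)c1` share a core and differ only in the group on the aromatic ring. In a functional assay on L5178Y cells (Mus musculus) for inhibition (on this read-out higher numbers stand for higher potency (the scale is a negative logarithm) and lower numbers for lower potency), compound 1 gives 5.61, while compound 2 gives 6.96, the higher of the two numbers; the step of a number 1.35 log units higher from compound 1 to compound 2 (beyond the scatter) is large. Compound 3 `CC1(C)N=C(N)N=C(N)N1c1cccc(Br)c1` carries bromo in place of acetyl on an aromatic carbon. Among the measured compounds shown here, the only measured step, from compound 1 to compound 2, shows that the group at this position can shift potency widely, but no step involves bromo itself, so only a small change is expected: a number 0.04 log units higher from compound 2 to compound 3 (within the scatter). Compound 3 is therefore estimated at 7, between 6.2 and 7.8.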

Compound 3, logarithm of the reciprocal of the active concentration, log(1/C): 8.42
Compound 3: the middle estimate sits 1.42 log units below what was measured, outside the stated range (above it).
By their numbers in this assay, from the lowest: compound 1; then compound 2; then compound 3.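

Bromo in place of acetyl gives a further large rise (a number 1.46 log units higher from compound 2 to compound 3 (beyond the scatter)), and bromo in place of sulfamoyl gives the widest gap so far (a number 2.81 log units higher from compound 1 to compound 3 (beyond the scatter)). In this assay, this position therefore tolerates more than the first two compounds suggested, and bromo, a single heavy atom with no hydrogen-bond donor or acceptor, ranks first of the three. No measurement here accounts for this rise. Going by these compounds, it remains open whether chloro, iodo, methyl or an amine at this position would match bromo, and whether bromo would keep its number elsewhere on the ring.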